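Phenyl in place of 5-methylthiophen-2-yl

The source may hold more compounds than are shown below. What is called first, only, known or untested is meant among the compounds shown, and "the series" means these compounds.

Measured in a functional assay on MGC-803 cells (Homo sapiens) for antiproliferative activity, read by MTT assay, with a stated time of 72 h; on this read-out higher numbers stand for weaker inhibition and lower numbers for stronger inhibition:
compound 1 `O=C(NO)c1ccc(NCc2nc(-c3ccccc3)nn2-c2ccc(Br)cc2)cc1`: 9300 nM
compound 2 `O=C(NO)c1ccc(NCc2nc(-c3ccccc3)nn2-c2cccc(Cl)c2)cc1`: 13700 nM
compound 3 `Cc1ccc(-c2nc(CNc3ccc(C(=O)NO)cc3)n(-c3ccccc3)n2)s1`: 8450 nM

The three values lie close together, and compound 3, at 8450 nM, stands within the scatter of both others. The still unmeasured compound 4 `O=C(NO)c1ccc(NCc2nc(-c3ccccc3)nn2-c2ccccc2)cc1` keeps the rest of compound 3 and carries phenyl in place of 5-methylthiophen-2-yl on an aromatic carbon. For the measured compounds named here, no measured step covers this exchange directly. Going by the values given here, the only measured step, a 1.5-fold higher number from compound 1 to compound 2 (0.17 log units; within the scatter), concerns 3-chlorophenyl in place of 4-bromophenyl on an aromatic nitrogen, a different place, and it stays within the scatter. Still, compound 1 at 9300 nM and compound 2 at 13700 nM already carry phenyl on the aromatic carbon in question, and neither value is set apart from compound 3 at 8450 nM by more than the scatter. In this assay, therefore, no step beyond the scatter is expected. The estimated step is a 1.2-fold higher number from compound 3 to compound 4 (0.07 log units; within the scatter). For compound 4 the estimated value is 10000 nM, with an expected range of 4500 nM to 22000 nM.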

Compound 4, half-maximal inhibitory concentration: 17700 nM
Compound 4: middle estimate off by 1.8-fold (0.25 log units), on the low side; the measured number falls inside the stated range.
By their numbers in this assay, from the lowest: compounds 3, 1, 2 and 4 (each within the scatter of the next, the first and the last beyond it).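

In this assay, phenyl in place of 5-methylthiophen-2-yl on this aromatic carbon gives a 2.1-fold higher number from compound 3 to compound 4 (0.32 log units; beyond the scatter), a modest step and the only one among those shown that passes the scatter. Hydrogen in place of chloro gives a 1.3-fold higher number from compound 2 to compound 4 (0.11 log units; within the scatter), and hydrogen in place of bromo gives a 1.9-fold higher number from compound 1 to compound 4 (0.28 log units; within the scatter), so neither halogen exchange on the phenyl ring at the aromatic nitrogen can be told from the scatter. Nothing available here accounts for the step at the aromatic carbon.

Still open, from the compounds shown here alone, is whether the step belongs to the ring sulfur or to the methyl group, which thiophen-2-yl without the methyl would help to separate. Also open, going by these compounds, is how this assay would read with an amine or a carboxylic acid on the ring at this aromatic carbon.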